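The source may report more compounds than this note shows. Statements on the series, on what has been measured and on what is new or still open speak of the compounds shown alone.

Compound 1 `CCCc1nc(-c2ccccc2)c(CNCCCN2CCN(c3ccccc3OC)CC2)o1`: 41%
Compound 2 `CCCc1nc(-c2ccccc2)c(CNCCCN2CCN(c3cccc(C)c3)CC2)o1`: 47.8%

In an assay on HEK293 cells for inhibition of Voltage-dependent T-type calcium channel subunit alpha-1G (Homo sapiens), read by fluorescence, tested at 10 uM (a lower number here means less inhibition, a higher number more inhibition at the concentration tested (going by the name of the read-out)), compound 2 gives 47.8%, and compound 1 gives 41%. Within the data shown here, the single measured step, a number 6.8 percentage points higher from compound 1 to compound 2 (within the scatter), exchanges one aromatic group for another on the amine nitrogen in the ring and stays within the scatter, so compound 2 and compound 1 cannot be told apart on these two numbers.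

Compound 3 `CCCc1nc(-c2ccccc2)c(CNCCCN2CCN(c3ccc(Cl)cc3)CC2)o1` carries the change (4-chlorophenyl in place of 3-methylphenyl on an amine nitrogen in a ring). Among the measured compounds shown here, the only step that bears on it is a number 6.8 percentage points higher from compound 1 to compound 2 (within the scatter), which concerns the same position and was small. For the measured compounds named here, no measured compound carries a 4-chlorophenyl group, so nothing shows how this particular group behaves. The step from compound 2 to compound 3 is therefore expected to stay within the scatter, a number 0.2 percentage points higher from compound 2 to compound 3 (within the scatter). Compound 3 is estimated at 48%, with a range from 30% to 66%.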

Compound 3, a percentage reported as inhibition, at one concentration (the size of the read-out at that concentration, not a potency): 63.3%
For compound 3 the middle estimate is 15.3 percentage points below the measured one; the measured number falls inside the stated range.
By their numbers in this assay, from the lowest: compounds 1 and 2 (each within the scatter of the next); then compound 3.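

At this position, on an amine nitrogen in a ring, the choice of aromatic group does register in this assay: 4-chlorophenyl gives a number 15.5 percentage points higher from compound 2 to compound 3 (beyond the scatter) and a number 22.3 percentage points higher from compound 1 to compound 3 (beyond the scatter), whereas the exchange seen earlier stayed within the scatter. The 3-methylphenyl and 4-chlorophenyl groups match in heavy atoms, in their single six-membered aromatic ring of carbon only and in having no hydrogen-bond donors or acceptors, so these counts do not separate them. Nothing at hand accounts for these steps.

The compounds shown leave open whether the chlorine or its place on the ring goes with the higher number, since they include no phenyl, 3-chlorophenyl or 2-chlorophenyl group at this nitrogen. They also leave open how a 4-fluorophenyl or 4-bromophenyl group would compare.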